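Cytotoxicity of a Nucleoside Pair with Five-Membered Heteroaryl Groups

The source may hold more compounds than are shown below. What is called first, only, known or untested is meant among the compounds shown, and "the series" means these compounds.

The three measured compounds share a nucleoside core carrying a substituent on the five-membered ring. Compound 1, `COc1ncnc2c1c(I)cn2[C@@H]1O[C@H](CO)[C@@H](O)[C@H]1O`, bears an iodine at that position and in an ADME assay on BJ cells (Homo sapiens), read by MTT assay, with a stated time of 72 h (a lower number here means a stronger inhibitor, a higher number a weaker inhibitor), compound 1 gives 91000 nM. Compound 3, `O=c1[nH]cnc2c1c(-c1cc3ccccc3o1)cn2[C@@H]1O[C@H](CO)[C@@H](O)[C@H]1O`, carries a benzofuranyl group, and in this assay compound 3 gives 62700 nM. Compound 2, `CNc1ncnc2c1c(-c1ccsc1)cn2[C@@H]1O[C@H](CO)[C@@H](O)[C@H]1O`, carries a thiophen-3-yl group. In this assay compound 2 gives > 100000 nM, which is a limit of the assay and not a number. Compound 2 therefore stands at the upper limit of the values shown, the weakest end of the range, as the limit of > 100000 nM in this assay, at which 1 of the 3 values shown sits, records for one of the three values. Within the data shown here, no single-change step between measured compounds is available.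

Compound 4, `CNc1ncnc2c1c(-c1ccoc1)cn2[C@@H]1O[C@H](CO)[C@@H](O)[C@H]1O`, differs from compound 2 in one place: furan-3-yl in place of thiophen-3-yl on an aromatic carbon. The exchange keeps the size and shape of the substituent and its donor and acceptor count; the step from compound 2 to compound 4 is therefore expected to stay within the usual scatter, with no clear direction, and compound 4 may well also return only a limit. Compound 4 is expected to give 100000 nM, with a range from 40000 nM to 250000 nM. The estimated step of a number no higher from compound 2 to compound 4 (the limit leaves the size open) is expected to be none beyond the scatter.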

Compound 4, half-maximal inhibitory concentration: 96300 nM
Compound 4: middle estimate off by 1.0-fold (0.02 log units), on the high side; low and high end bracket the measured number.
By their numbers in this assay, from the lowest: compounds 3, 1 and 4 (each within the scatter of the next). At a limit, above all of these: compound 2.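

In this assay, among these compounds, furan-3-yl in place of thiophen-3-yl on an aromatic carbon gives an at least 1.0-fold lower number from compound 2 to compound 4 (0.01 log units; that floor lies within the scatter), the first step in this set that can be read at all, though only as a floor. In this assay, going by these compounds, compound 2 gives > 100000 nM, which is a limit and not a number, so the true size of the step stays unknown: the limit of > 100000 nM in this assay, at which 1 of the 4 values shown sits. Compound 4 gives 96300 nM, a number rather than a limit, which allows the oxygen-bearing ring at this place to be read directly. The printed floor of the step shows no change beyond the scatter and does not exclude one.

Compound 1 and compound 3 differ from compound 4 in more than one place, so they cannot show how much of the value depends on this substituent alone. On these data alone, whether a phenyl ring at this place, or an amine or a carboxylic acid carried on the furan-3-yl ring, would shift the number in this assay remains open.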